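Primary amine in place of methoxy on the benzylic chain

The compounds below may be only part of what the source reports. "The series", "measured", "known", "first", "only" and "open" are said of these compounds alone.

Compound 1 `COCc1ccc(-n2c(SC(C)c3ccccc3)nc3c(cnn3C)c2=O)cc1` is the higher of the two numbers measured in an assay on isolated protein for inhibition of retinal dehydrogenase 2 (Homo sapiens), tested at 5 uM (on this read-out lower numbers stand for less inhibition and higher numbers for more inhibition at the one concentration tested (going by the name of the read-out)), where compound 1 gives 61%. Compound 2 `COc1ccc(C(C)Sc2nc3c(cnn3C)c(=O)n2-c2ccccc2)cc1` gives 41% in this assay, a lower number that lies beyond the usual scatter. Compound 3 `CC(Sc1nc2c(cnn2C)c(=O)n1-c1ccc(CN)cc1)c1ccccc1` is not yet measured; it differs from compound 1 by amino in place of methoxy on a saturated chain carbon bound to an aromatic carbon. Within the data shown here, no step between measured compounds isolates this change, so the direction is open. A modest drop is expected, a step from compound 1 to compound 3 of a number 11 percentage points lower from compound 1 to compound 3 (beyond the scatter). Compound 3 is accordingly estimated at 50%, within a range of 25% to 75%.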

Compound 3, a percentage reported as inhibition, at one concentration (the size of the read-out at that concentration, not a potency): 64%
Compound 3: the middle estimate sits 14 percentage points below what was measured, and the stated range covers the measured number.
By their numbers in this assay, from the lowest: compound 2; then compounds 1 and 3 (each within the scatter of the next).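

In this assay, amino in place of methoxy on a saturated chain carbon bound to an aromatic carbon gives a number 3 percentage points higher from compound 1 to compound 3 (within the scatter) and so leaves the two groups unseparated at this position. The read-out thus stays in the same range with 4-(aminomethyl)phenyl, which carries a hydrogen-bond donor that 4-(methoxymethyl)phenyl lacks. Nothing at hand bears on why these two groups read alike.

The compounds shown leave open how a carboxylic acid, a tertiary amine or a longer chain would read at this place.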